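The source may report more compounds than this note shows. Statements on the series, on what has been measured and on what is new or still open speak of the compounds shown alone.

Measured so far:
Compound 1 `Cn1ccnc1NC(=O)c1cccc(Nc2ncc(F)c(Nc3ccc(F)cc3)n2)c1` — 13100 nM
Compound 2 `O=C(Nc1cc(Cl)cc(Cl)c1)c1cccc(Nc2ncc(F)c(Nc3ccc(F)cc3)n2)c1` — 20700 nM
Compound 3 `O=C(Nc1cccc(Nc2ncc(F)c(Nc3ccc(F)cc3)n2)c1)c1cnccn1` — 20100 nM

In a functional assay on KBVIN cells (Homo sapiens) for antiproliferative activity, read by sulforhodamine B assay, with a stated time of 3 days (a higher number here means a weaker inhibitor of growth, a lower number a stronger inhibitor of growth), compound 1 gives the lowest of the three numbers, though both its neighbours lie within the scatter of it: a 1.6-fold higher number from compound 1 to compound 2 (0.20 log units; within the scatter) and a 1.5-fold higher number from compound 1 to compound 3 (0.19 log units; within the scatter). Compound 4 `O=C(Nc1cccc(Nc2ncc(F)c(Nc3ccc(F)cc3)n2)c1)c1ccncc1` is not yet measured. It differs from compound 1 at the amide: ((pyridin-4-yl)carbonyl)amino in place of (1-methyl-1H-imidazol-2-yl)carbamoyl on an aromatic carbon. The step from compound 1 to compound 3 bears most directly on this, since it also turns the amide round and brings in a six-membered heteroaromatic ring, and it stayed within the scatter. Compound 2 and compound 3 also sit within the scatter of each other. So no step beyond the scatter is expected in this assay, and compound 4 is estimated at 18000 nM (range 8000 nM to 40000 nM), an expected step of a 1.4-fold higher number from compound 1 to compound 4 (0.14 log units; within the scatter).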

Compound 4, concentration for 50% growth inhibition: 4570 nM
Compound 4: middle estimate off by 3.9-fold (0.60 log units), on the high side; measured number outside the range, below it.
By their numbers in this assay, from the lowest: compound 4; then compounds 1, 3 and 2 (each within the scatter of the next).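

In this assay, this position can move the number beyond the scatter: a 2.9-fold lower number from compound 1 to compound 4 (0.46 log units; beyond the scatter), a 4.4-fold lower number from compound 3 to compound 4 (0.64 log units; beyond the scatter) and a 4.5-fold lower number from compound 2 to compound 4 (0.66 log units; beyond the scatter). The turned amide alone does not account for this, since compound 3 carries it too, and the step from compound 3 to compound 4 changes only the ring on the carbonyl carbon, pyridin-4-yl in place of pyrazin-2-yl. Nothing measured here explains the difference.

The compounds shown leave open what a plain phenyl ring or a piperidine on that carbonyl carbon would give, and so whether the ring nitrogen of the pyridin-4-yl group is needed at all.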